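The compounds below may be only part of what the source reports. "The series", "measured", "known", "first", "only" and "open" are said of these compounds alone.

Of the compounds shown here, three have so far been measured in a functional assay on P388 cells (Mus musculus) for inhibition (a higher number here means a weaker inhibitor, a lower number a stronger inhibitor), and a fourth awaits its turn. Compound 1 `C(=C\c1ccc2[nH]ccc2c1)\c1ccc2ccccc2c1` returns in this assay only a limit of the assay and not a number, > 5000 nM. Compound 2 `Cn1ccc2cc(/C=C\c3ccc4ccccc4c3)ccc21` is set apart from compound 1 by methyl in place of hydrogen on an aromatic nitrogen. In this assay compound 2 likewise gives a limit rather than a number, > 5000 nM. The step from compound 1 to compound 2 is thus a step that the two limits leave unreadable from compound 1 to compound 2, and it stays unreadable because the limit of > 5000 nM in this assay, at which 2 of the 3 values shown sit, hides whatever separates the two.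

Compound 3 `COc1cc(/C=C/c2c[nH]c3ccccc23)cc(OC)c1OC` rests on a different core; how the core of compound 3 differs from the core of compound 1 is not broken down here. In this assay, for the measured compounds named here, compound 3 gives 3230 nM, the only number among the three values.

Compound 4 `COc1cc(/C=C/c2cn(C)c3ccccc23)cc(OC)c1OC` has not been measured yet. It differs from compound 3 by methyl in place of hydrogen on an aromatic nitrogen. Going by the values given here, this is the same kind of change as the one from compound 1 to compound 2, with the added note that here the aromatic nitrogen lies two ring bonds from the ring atom that bears a large group. The earlier instance of the change offers no readable size, so the expectation for compound 4 leans on the value of compound 3 alone. Compound 4 is expected to give about 3000 nM in this assay, likely between 600 nM and 15000 nM. That estimate means an expected step from compound 3 to compound 4 of a 1.1-fold lower number from compound 3 to compound 4 (0.03 log units; within the scatter), small and within the usual scatter.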

Compound 4, half-maximal inhibitory concentration: 3090 nM
The estimate for compound 4 lay 1.0-fold (0.01 log units) below the measured number, within the range that was stated.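

In this assay, methyl in place of hydrogen on an aromatic nitrogen gives a 1.0-fold lower number from compound 3 to compound 4 (0.02 log units; within the scatter), so on this core the two compounds cannot be told apart. For the compounds shown here, this is the only instance of the change with a readable size, and a single instance does not show that the change would behave the same way on a different core, nor does it show that the nitrogen hydrogen and the methyl are interchangeable in general. The step on the core of compound 1 cannot be read, so the two cores offer no pair of sizes to compare, and the reason lies in a limit of the assay, which is not a number: the limit of > 5000 nM in this assay, at which 2 of the 4 values shown sit.

The compounds shown leave open whether a group other than methyl on that aromatic nitrogen, such as an ethyl, a longer chain or an acetyl, would set a compound apart from compound 3 in this assay. They also leave open how the number would respond if the methoxy groups gave way to a hydroxyl, an amine or a carboxylic acid.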